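Swapping 4-bromophenyl for 2,4-dichlorophenyl

The source may hold more compounds than are shown below. What is called first, only, known or untested is meant among the compounds shown, and "the series" means these compounds.

Values in a functional assay on HepG2 cells (Homo sapiens) for cytotoxicity, read by MTT assay, with a stated time of 24 h; on this read-out lower numbers stand for stronger inhibition and higher numbers for weaker inhibition:
- compound 1 `COc1cc(/C=C2\CN(C)C/C(=C\c3ccc(F)cc3)C2=O)cc(OC)c1`: 6140 nM
- compound 2 `COc1cc(/C=C2\CN(C)C/C(=C\c3ccc(Cl)cc3)C2=O)cc(OC)c1`: 5950 nM
- compound 3 `COc1cc(/C=C2\CN(C)C/C(=C\c3ccc(Br)cc3)C2=O)cc(OC)c1`: 4840 nM

Compound 3 stands level with the other two: a 1.2-fold lower number from compound 2 to compound 3 (0.09 log units; within the scatter) and a 1.3-fold lower number from compound 1 to compound 3 (0.10 log units; within the scatter) both lie within the scatter. Compound 4 `COc1cc(/C=C2\CN(C)C/C(=C\c3ccc(Cl)cc3Cl)C2=O)cc(OC)c1`, not yet measured, differs from compound 3 by 2,4-dichlorophenyl in place of 4-bromophenyl on a double-bonded chain carbon bound to a double-bonded ring carbon, with 2,4-dichlorophenyl in place of 4-bromophenyl on a double-bonded chain carbon bound to a double-bonded ring carbon. The remaining halogen exchange, a 1.0-fold lower number from compound 1 to compound 2 (0.01 log units; within the scatter), also stayed within the scatter. Among the compounds with values here, no measured compound carries a second chlorine, so the data do not cover that part of the change. In this assay, no step beyond the scatter is therefore expected. The expected move is a 1.1-fold lower number from compound 3 to compound 4 (0.02 log units; within the scatter). For compound 4 the estimated value is 4600 nM, with an expected range of 2300 nM to 9000 nM.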

Compound 4, half-maximal inhibitory concentration: 6250 nM
Estimate against measurement, compound 4: 1.4-fold (0.13 log units) below, within the range that was stated.
By their numbers in this assay, from the lowest: compounds 3, 2, 1 and 4 (each within the scatter of the next).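

In this assay, within the data shown here, the added chlorine gave the first reading of a second halogen on this aromatic ring, and it stayed within the scatter (a 1.1-fold higher number from compound 2 to compound 4 (0.02 log units; within the scatter)). The whole-group exchanges on the double-bonded chain carbon bound to a double-bonded ring carbon also stayed within the scatter (a 1.3-fold higher number from compound 3 to compound 4 (0.11 log units; within the scatter); a 1.0-fold higher number from compound 1 to compound 4 (0.01 log units; within the scatter)), so 2,4-dichlorophenyl stands level with the singly halogenated rings of compound 1, compound 2 and compound 3. No available evidence accounts for this level result.

All four compounds carry only halogens on this ring. Going by these compounds, whether an amine or a carboxylic acid there would move the number beyond the scatter remains open.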